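Fused bicyclic series: acetamido replaced by methylsulfanyl

The source may hold more compounds than are shown below. What is called first, only, known or untested is meant among the compounds shown, and "the series" means these compounds.

Measured so far:
compound 1 `Cc1nc2c(CCc3ccccc3)cccn2c1N` — 47%
compound 2 `CC(=O)Nc1c(C)nc2c(CCc3ccccc3)cccn12` — 40%
compound 3 `CCCN(CCC)c1c(C)nc2c(OCc3ccccc3)cccn12` — 60%

In a functional assay on the whole organism with Rattus norvegicus as the target, at a dose of 40 mg/kg by the intraperitoneal route (on this read-out lower numbers stand for less inhibition and higher numbers for more inhibition at the one dose given (going by the name of the read-out)), compound 2 gives 40%, the smallest number among the three. Against compound 1 this is a change a number 7 percentage points lower from compound 1 to compound 2 (within the scatter) and so carries no weight. Against compound 3 the gap is beyond the scatter, but compound 3 differs from compound 2 in two places, so only the two values themselves can be compared.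

Compound 4 `CSc1c(C)nc2c(CCc3ccccc3)cccn12` is not yet measured. It differs from compound 2 by methylsulfanyl in place of acetamido on an aromatic carbon. Within the data shown here, the only measured step at this site, a number 7 percentage points lower from compound 1 to compound 2 (within the scatter), was within the scatter, so no step beyond the scatter is expected here either. The estimated step is a number 5 percentage points higher from compound 2 to compound 4 (within the scatter), and compound 4 is expected to give about 45%, between 25% and 65% in this assay.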

Compound 4, a percentage reported as inhibition, in the whole organism at one dose (the size of the read-out at that dose, not a potency): 28%
Compound 4: middle estimate off by 17 percentage points, on the high side; the measured number falls inside the stated range.
By their numbers in this assay, from the lowest: compound 4; then compounds 2 and 1 (each within the scatter of the next); then compound 3.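

In this assay, among these compounds, the group on this aromatic carbon does matter: methylsulfanyl in place of acetamido gives a number 12 percentage points lower from compound 2 to compound 4 (beyond the scatter) and methylsulfanyl in place of amino gives a number 19 percentage points lower from compound 1 to compound 4 (beyond the scatter) and these are the first steps at this site to lie beyond the scatter. Methylsulfanyl enters with sulfur and no hydrogen-bond donor, where acetamido carries one. No measurement at hand accounts for the lower number. Going by these compounds, whether the sulfur or the missing donor goes with the step remains open. On these data alone, how a methoxy group or a longer ethylsulfanyl chain on this carbon would read also remains open.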